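The source may hold more compounds than are shown below. What is called first, only, known or untested is meant among the compounds shown, and "the series" means these compounds.

Measured so far in an assay on isolated protein for displacement of a labelled ligand from acyl-CoA:cholesterol acyltransferase (Oryctolagus cuniculus); on this read-out lower numbers stand for stronger inhibition and higher numbers for weaker inhibition: compound 1 `CC(C)c1cccc(C(C)C)c1NC(=O)Nc1nc2ccccc2n1-c1ccc(Cl)cc1` gives 280 nM; compound 2 `CC(C)c1cccc(C(C)C)c1NC(=O)Nc1nc2ccccc2n1-c1ccccc1C(F)(F)F` gives 72 nM; compound 3 `CC(C)c1cccc(C(C)C)c1NC(=O)Nc1nc2ccccc2n1-c1ccccc1N(C)C` gives 41 nM.

Compound 3 has the lowest number of the three; compound 2 lies within the scatter of it, while compound 1 sits further off, see a 6.8-fold lower number from compound 1 to compound 3 (0.83 log units; beyond the scatter). Compound 4 `Cc1ncccc1-n1c(NC(=O)Nc2c(C(C)C)cccc2C(C)C)nc2ccccc21` differs from compound 3 by 2-methylpyridin-3-yl in place of 2-(dimethylamino)phenyl on an aromatic nitrogen. Among the measured compounds shown here, no measured step swaps one of these aryl groups for a pyridine. For the measured compounds named here, the steps that bear on the change are a 3.9-fold lower number from compound 1 to compound 2 (0.59 log units; beyond the scatter) and a 6.8-fold lower number from compound 1 to compound 3 (0.83 log units; beyond the scatter), both modest, and a 1.8-fold lower number from compound 2 to compound 3 (0.24 log units; within the scatter), within the scatter. Compound 4 keeps a substituted ring on that aromatic nitrogen, as compounds 2 and 3 do, so a number near theirs is expected, with the step of a 1.6-fold higher number from compound 3 to compound 4 (0.20 log units; within the scatter). Compound 4 is estimated at 65 nM, range 20 nM to 220 nM.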

Compound 4, half-maximal inhibitory concentration: 100 nM
For compound 4 the middle estimate is 1.5-fold (0.19 log units) below the measured one; the range from low to high includes it.
By their numbers in this assay, from the lowest: compounds 3, 2 and 4 (each within the scatter of the next, the first and the last beyond it); then compound 1.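

A ring with a hetero atom is accepted on this aromatic nitrogen: in this assay 2-methylpyridin-3-yl keeps a gain over 4-chlorophenyl, a 2.8-fold lower number from compound 1 to compound 4 (0.45 log units; beyond the scatter), and stays within the scatter of 2-(trifluoromethyl)phenyl, a 1.4-fold higher number from compound 2 to compound 4 (0.14 log units; within the scatter). Against 2-(dimethylamino)phenyl it does lose ground, a 2.4-fold higher number from compound 3 to compound 4 (0.39 log units; beyond the scatter), the first step beyond the scatter among the three substituted rings to go towards weaker inhibition. No measurement on hand accounts for these steps. As far as these compounds go, whether the ring nitrogen or the methyl group carries the difference stays open; 2-methylphenyl and unsubstituted pyridin-3-yl on the same nitrogen would separate the two.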